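Swapping an indole for a vinylphenyl on a shared core

The source may hold more compounds than are shown below. What is called first, only, known or untested is meant among the compounds shown, and "the series" means these compounds.

Measured so far:
compound 1 `Cn1ccc2cc(-c3cc4nccc(-c5ccc(F)cc5)n4n3)ccc21` — 4780 nM
compound 2 `COc1cc(-c2ccnc3cc(-c4c[nH]c5ccccc45)nn23)cc(OC)c1OC` — 40 nM

Of the compounds shown here, two have been measured in a functional assay on B16-F0 cells (Mus musculus) for inhibition, read by CCK-8 assay, with a stated time of 48 h; a lower number here means a stronger inhibitor, a higher number a weaker inhibitor. Compound 1 `Cn1ccc2cc(-c3cc4nccc(-c5ccc(F)cc5)n4n3)ccc21` gives 4780 nM, whereas compound 2 `COc1cc(-c2ccnc3cc(-c4c[nH]c5ccccc45)nn23)cc(OC)c1OC` gives 40 nM. Compound 2 therefore holds the lowest number of the two, and its gap to compound 1 lies well beyond the scatter of the measurement. Among the compounds with values here, the two compounds differ in more than one place, so no single step between them can be read.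

Compound 3 `C=Cc1ccc(-c2cc3nccc(-c4cc(OC)c(OC)c(OC)c4)n3n2)cc1` is the next compound to be measured in this assay. It keeps the core of compound 2 together with its trimethoxyphenyl group, and differs from compound 2 in one place: 4-vinylphenyl in place of 1H-indol-3-yl on an aromatic carbon. The indole that leaves carries the only hydrogen-bond donor of that group, and the 4-vinylphenyl that enters has none. Within the data shown here, no measured pair shows what this exchange does, so the expectation rests on compound 2 alone. A moderate loss of potency is expected, with a step of a 6.3-fold higher number from compound 2 to compound 3 (0.80 log units; beyond the scatter) that should exceed the scatter. Compound 3 is thus estimated at 250 nM, within a range of 60 nM to 1500 nM.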

Compound 3, half-maximal inhibitory concentration: 788 nM
The estimate for compound 3 lay 3.2-fold (0.50 log units) below the measured number, within the range that was stated.
By their numbers in this assay, from the lowest: compound 2; then compound 3; then compound 1.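

In this assay, within the data shown here, placing 4-vinylphenyl instead of 1H-indol-3-yl on this aromatic carbon of the five-membered aromatic ring gives a 20-fold higher number from compound 2 to compound 3 (1.29 log units; beyond the scatter), the first single-place change that can be read in this set. With the core and the trimethoxyphenyl group held constant, the step shows that the number is sensitive to the group at this position, and that this exchange carries a large penalty. The change alters several things at once, removing the five-membered aromatic ring and the hydrogen-bond donor of the indole and adding a double bond outside aromatic rings, and no measurement available here identifies which of these matters.

The compounds shown leave open whether a plain phenyl, a 4-ethylphenyl or a 4-aminophenyl at this position would give a number closer to that of compound 2 or compound 3, which would help separate the part played by the vinyl group from that of the indole. Steps involving compound 1 cannot be read, since it differs from the others in more than one place, so the effect of replacing the trimethoxyphenyl group also remains open.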